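Swapping a phenoxy for a bromo on an oxazoline scaffold

The source may report more compounds than this note shows. Statements on the series, on what has been measured and on what is new or still open speak of the compounds shown alone.

Measured so far:
- Compound 1, `c1ccc(Oc2ccccc2C2=NC(c3ccccc3)CO2)cc1`, gives 5.61.
- Compound 2, `Clc1ccc(C2=NC(c3ccccc3)CO2)cc1`, gives 4.48.
- Compound 3, `Clc1cccc(Cl)c1C1=NC(c2ccccc2)CO1`, gives 3.69.

These three compounds share a common core and were compared in a physicochemical assay for lipophilicity; a higher number here means a more lipophilic compound, a lower number a more polar compound. Compound 1 stands highest of the three numbers. Its nearest neighbour is compound 2, whose value lies well below, beyond the scatter of repeat measurements; the furthest is compound 3, lower still and also beyond the scatter.

The step of interest leads from compound 1 to compound 4, `Brc1ccccc1C1=NC(c2ccccc2)CO1`, which has not yet been measured in this assay. The change between the two structures is this: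

bromo in place of phenoxy on an aromatic carbon

For the measured compounds named here, no pair of measured compounds differs by just this change, so the size of the step can only be expected, not read off. Since compound 2 carries a single halogen on the outer ring and gives 4.48, a value clearly below compound 1, compound 4 is expected to land in a similar region. The estimated step of a number 1.11 log units lower from compound 1 to compound 4 (beyond the scatter) is therefore a drop well beyond the scatter. Compound 4 is estimated at 4.5, within a range from 4 to 5.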

Compound 4, partition coefficient: 3.69
Beside the measured number, compound 4's estimate is 0.81 log units above it; measured number below the stated range.
By their numbers in this assay, from the lowest: compounds 3 and 4 (each within the scatter of the next); then compound 2; then compound 1.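

For the compounds shown here, until now, no two measured compounds differed in a single place, so this assay had given no direct size for any one change on this shared core. Exchanging phenoxy for bromo on an aromatic carbon, ortho to a large group, now gives the first such size, a number 1.92 log units lower from compound 1 to compound 4 (beyond the scatter), showing that the read-out can respond strongly to what sits at this position when 7 heavy atoms, including an aromatic ring, give way to 1 heavy atom. Nothing measured here explains why the step has this size.

This single pair cannot show which part of the change matters most: the loss of the outer ring, the loss of the linking oxygen, the arrival of bromine or the drop in the number of heavy atoms. A phenyl group attached directly at this carbon, a methoxy group or a plain hydrogen in the same place would help to pull those parts apart, and an amine there would show how the number moves with a quite different kind of substituent.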